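A few compounds are considered here, and "the series" means these few. Any claim that something is new, unique, unknown or untested is made for them only; others in the source may bear on it.

Compound 1, `Cn1nc2c(=O)n(CC3(O)CCN(Cc4ccc(-c5ccco5)cc4Cl)CC3)cnc2c1-c1ccc(CNC(=O)C(F)(F)F)cc1`, is tested in an assay on isolated protein for inhibition of ubiquitin carboxyl-terminal hydrolase 7 (Homo sapiens), with stated times of 30 min and 2 h (a lower number here means a stronger inhibitor, a higher number a weaker inhibitor), where compound 1 gives 2060 nM. Among the three compounds with numbers, compound 1 stands highest, that is, it is the weakest inhibitor of the three. Compound 2, `Cn1nc2c(=O)n(CC3(O)CCN(Cc4ccc(-c5ccco5)cc4Cl)CC3)cnc2c1-c1ccc(Cl)cc1`, gives 143 nM in this assay, and compound 3, `Cn1nc2c(=O)n(CC3(O)CCN(Cc4ccc(-c5ccc[nH]5)cc4Cl)CC3)cnc2c1-c1ccc(CN)cc1`, gives 193 nM; compound 3 differs from compound 1 in more than one place, so its value is only set alongside, not treated as a step. Compound 4, `Cn1nc2c(=O)n(CC3(O)CCN(Cc4ccc(-c5ccco5)cc4Cl)CC3)cnc2c1-c1ccc(OC(F)F)cc1`, is the same as compound 1 apart from one change: difluoromethoxy in place of (((trifluoromethyl)carbonyl)amino)methyl on an aromatic carbon. The change sits on an aromatic carbon of a six-membered aromatic ring of carbon only, para to a large group. Among the measured compounds shown here, one measured step bears on it: a 14-fold lower number from compound 1 to compound 2 (1.16 log units; beyond the scatter), where the same group left and chloro entered. Difluoromethoxy, like chloro, brings in a group with fewer heavy atoms and no hydrogen-bond donor, so a drop in number of similar size is expected, a 10-fold lower number from compound 1 to compound 4 (1.01 log units; beyond the scatter). Compound 4 is therefore estimated at 200 nM, with a likely range from 70 nM to 600 nM.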

Compound 4, half-maximal inhibitory concentration: 179 nM
The estimate for compound 4 lay 1.1-fold (0.05 log units) above the measured number, and the stated range covers the measured number.
By their numbers in this assay, from the lowest: compounds 2, 4 and 3 (each within the scatter of the next); then compound 1.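

The step of a 12-fold lower number from compound 1 to compound 4 (1.06 log units; beyond the scatter) is a second large one at this position, so the lower number seen with chloro is not peculiar to chloro: two different replacements for (((trifluoromethyl)carbonyl)amino)methyl now give it. The step of a 1.3-fold higher number from compound 2 to compound 4 (0.10 log units; within the scatter) lies within the scatter, so at this aromatic carbon the two groups cannot be told apart in this assay, even though difluoromethoxy brings an oxygen and two fluorines in place of one chlorine. Nothing measured here explains this shared level or the gap to compound 1.

Still open, as far as these compounds go, is whether the level shared by compound 2 and compound 4 also holds for a different kind of group here, such as a nitrile or a carboxylic acid. Also open, from the compounds shown here alone, is which part of the departing group goes with its higher number: the carbonyl, the trifluoromethyl or the amide hydrogen.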